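The compounds below may be only part of what the source reports. "The series", "measured", "known", "first", "only" and "open" are said of these compounds alone.

In a functional assay on NCI-H226 cells (Homo sapiens) for inhibition, read by MTT assay, with a stated time of 48 h, tested at 10 uM (a lower number here means less inhibition, a higher number more inhibition at the concentration tested (going by the name of the read-out)), three compounds have been measured:
compound 1 `COc1cc(NC(=O)Nc2cc(Nc3ccc(C(C)(C)C)cc3)ncn2)cc(OC)c1` gives 47.7%
compound 2 `COc1cc(NC(=O)Nc2cc(Nc3cc(F)ccc3OC)ncn2)cc(OC)c1` gives 37.7%
compound 3 `COc1cc(NC(=O)Nc2cc(Nc3ccc(Br)cc3OC)ncn2)cc(OC)c1` gives 25.7%

Compound 3 stands lowest of the three; the nearest step is a number 12 percentage points lower from compound 2 to compound 3 (beyond the scatter) and the furthest is a number 22 percentage points lower from compound 1 to compound 3 (beyond the scatter). Compound 4 `COc1cc(NC(=O)Nc2cc(Nc3ccc(OC)c(C)c3)ncn2)cc(OC)c1` differs from compound 3 in one place: 4-methoxy-3-methylphenyl in place of 4-bromo-2-methoxyphenyl on a nitrogen on an aromatic ring. Every measured step alters the same group on the same nitrogen, and a number 10 percentage points lower from compound 1 to compound 2 (within the scatter) shows that such a swap can also leave the number within the scatter. Nothing measured carries the entering group, so the size and direction of the step in this assay are uncertain; a modest rise toward the middle of the range seems more likely than a further fall, as compound 3 already stands lowest with 25.7%. Compound 4 is therefore expected to give 38%, between 20% and 56%, an estimated step of a number 12.3 percentage points higher from compound 3 to compound 4 (beyond the scatter).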

Compound 4, a percentage reported as inhibition, at one concentration (the size of the read-out at that concentration, not a potency): 39.7%
The estimate for compound 4 lay 1.7 percentage points below the measured number; the range from low to high includes it.
By their numbers in this assay, from the lowest: compound 3; then compounds 2, 4 and 1 (each within the scatter of the next).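

In this assay, placing 4-methoxy-3-methylphenyl on this nitrogen gives a number 14 percentage points higher from compound 3 to compound 4 (beyond the scatter) even though both groups count the same number of heavy atoms, so a swap of equal size can still move the number here. The other two steps, a number 2 percentage points higher from compound 2 to compound 4 (within the scatter) and a number 8 percentage points lower from compound 1 to compound 4 (within the scatter), leave compound 3 as the only one standing apart, the lowest of the four. No available measurement explains why this group differs from the others.

As far as these compounds go, it remains open whether the low number of compound 3 goes with its bromine or with the group as a whole. From the compounds shown here alone, how an aromatic ring carrying an amine or a carboxylic acid would behave on this nitrogen also remains open.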